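Adding a second trifluoromethyl to the urea aryl

This account rests on a few compounds, and the source may have more. Where it says the series, first, only, none or still open, it means among the compounds named here.

Compound 1 `O=C(Nc1cccc(-n2cc(-c3ccncc3)c(-c3ccc(Cl)c(O)c3)n2)c1)Nc1cc(C(F)(F)F)cc(C(F)(F)F)c1`: 8460 nM
Compound 2 `COc1cc(-c2nn(-c3cccc(NC(=O)Nc4cccc(C(F)(F)F)c4)c3)cc2-c2ccncc2)ccc1Cl`: 3480 nM

Of the compounds shown here, two have been measured in a functional assay on UACC-62 cells (Homo sapiens) for inhibition, read by sulforhodamine B assay, with a stated time of 48 h; on this read-out higher numbers stand for lower toxicity in this test and lower numbers for higher toxicity in this test. Compound 1 gives 8460 nM, and compound 2 gives 3480 nM. Compound 2 thus stands at the lowest of the two numbers, its nearest neighbour being compound 1 with a higher number, a gap that lies beyond the scatter. The two differ in more than one place, so no single change can be tied to that gap.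

Compound 3 `COc1cc(-c2nn(-c3cccc(NC(=O)Nc4cc(C(F)(F)F)cc(C(F)(F)F)c4)c3)cc2-c2ccncc2)ccc1Cl` has not yet been measured. It differs from compound 2 in one place: trifluoromethyl in place of hydrogen on an aromatic carbon. The same trifluoromethyl pattern on the urea aryl is present in compound 1, but compound 1 also carries a hydroxyl instead of the methoxy group found in compound 2 and compound 3, so the effect of this change alone cannot be read from the measured pair.

For compound 3 the step of a 1.4-fold higher number from compound 2 to compound 3 (0.14 log units; within the scatter) is expected to be small, possibly toward a slightly higher number, and likely within the scatter. Compound 3 is accordingly estimated at 4800 nM, with a range from 1800 nM to 13000 nM.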

Compound 3, concentration lethal to 50% of the cells: 3780 nM
Estimate against measurement, compound 3: 1.3-fold (0.10 log units) above; the range from low to high includes it.
By their numbers in this assay, from the lowest: compounds 2 and 3 (each within the scatter of the next); then compound 1.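

In this assay, trifluoromethyl in place of hydrogen on an aromatic carbon of the urea aryl, meta to a trifluoromethyl group, gives a 1.1-fold higher number from compound 2 to compound 3 (0.04 log units; within the scatter), so this position accepts the added group without a change that can be told from the scatter. The new compound also supplies a comparison that differs in one place at the oxygen on the aromatic ring: with the urea aryl held the same, methyl in place of hydrogen on that oxygen gives a 2.2-fold lower number from compound 1 to compound 3 (0.35 log units; beyond the scatter), a modest step that lies beyond the scatter, so in this pair the difference in the read-out belongs to the oxygen substituent and not to the urea aryl. No measurement is available that explains either step.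

As far as these compounds go, whether the step at the oxygen holds when the urea aryl carries a single trifluoromethyl remains open, as does whether a nitrile, an amine or a carboxylic acid at the new position would behave as trifluoromethyl does. From the compounds shown here alone, it is also open what a longer chain on the oxygen, in place of methyl, would do to the number.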